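Pyridin-2-yl to 4-acetylphenyl: expected inhibition of compound 4

The compounds below may be only part of what the source reports. "The series", "measured", "known", "first", "only" and "open" are said of these compounds alone.

Compound 1 `O=C1CCC(N2C(=O)c3ccc(Nc4ccccn4)cc3C2=O)C(=O)N1`: 9%
Compound 2 `C=C(OCC)c1ccc(Nc2cccc3c2C(=O)N(C2CCC(=O)NC2=O)C3=O)cc1`: 10%
Compound 3 `CCCCCc1ccc(Nc2cccc3c2C(=O)N(C2CCC(=O)NC2=O)C3=O)cc1`: 23%

In an assay on FRT-Jurkat cells for inhibition of nuclear factor NF-kappa-B complex (Homo sapiens), read by flow cytometry, with a stated time of 24 h, tested at 10 uM (a higher number here means more inhibition at the concentration tested (going by the name of the read-out), a lower number less inhibition), compound 1 gives the lowest of the three numbers. Compound 2 lies within the scatter of compound 1, while compound 3 lies beyond it. Going by the values given here, the only measured step, a number 13 percentage points higher from compound 2 to compound 3 (beyond the scatter), exchanges a pentyl for a 1-ethoxyethenyl on an aromatic carbon; it does not touch the nitrogen on the aromatic ring that is changed here.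

Compound 4 `CC(=O)c1ccc(Nc2ccc3c(c2)C(=O)N(C2CCC(=O)NC2=O)C3=O)cc1` differs from compound 1 by 4-acetylphenyl in place of pyridin-2-yl on a nitrogen on an aromatic ring. Among the compounds with values here, no measured step bears on this change, so no direction is secured. Compound 4 is therefore expected to stay near compound 1, with a step of a number 5 percentage points higher from compound 1 to compound 4 (within the scatter) that need not exceed the scatter, and an estimated 14% in this assay, between 2% and 32%.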

Compound 4, a percentage reported as inhibition, at one concentration (the size of the read-out at that concentration, not a potency): -2%
Compound 4: middle estimate off by 16 percentage points, on the high side, outside the stated range (below it).
By their numbers in this assay, from the lowest: compound 4; then compounds 1 and 2 (each within the scatter of the next); then compound 3.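

In this assay, going by these compounds alone, the change from pyridin-2-yl to 4-acetylphenyl on a nitrogen on an aromatic ring gives a number 11 percentage points lower from compound 1 to compound 4 (beyond the scatter) and is the first step read at this place, which the earlier compounds could not show. It sets a downward direction for this change, with compound 4 at -2% and thus on the negative side of zero. Nothing measured here accounts for this step. The compounds shown leave open whether a plain phenyl, or a phenyl carrying an amine or a carboxylic acid in place of the acetyl, would stay with compound 4 or return towards compound 1.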